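The source may hold more compounds than are shown below. What is called first, only, known or untested is meant among the compounds shown, and "the series" means these compounds.

Working notes on the series. Compound 1 `CCOC(=O)c1c(-c2ccc(OC)cc2)[nH]c2cccc(OC)c2c1=O`, compound 2 `CCOC(=O)c1c(-c2cccc(OC)c2)[nH]c2cc(OC)ccc2c1=O` and compound 3 `CCOC(=O)c1c(-c2ccccc2C)[nH]c2cccc(OC)c2c1=O` share one core and differ in the aryl group and the position of the methoxy group. In a physicochemical assay for solubility, in phosphate buffer, at pH 7.4 (a higher number here means a more soluble compound, a lower number a less soluble compound), compound 1 gives > 100000 nM, which is a limit of the assay and not a number. In this assay compound 2 gives > 100000 nM, again a limit. In this assay compound 3 gives > 100000 nM, likewise a limit. Compound 3 therefore stands at the limit of > 100000 nM in this assay, at which 3 of the 3 values shown sit, together with every other value shown. Going by the values given here, the only step between measured compounds, 2-methylphenyl in place of 4-methoxyphenyl on an aromatic carbon, is a step that the two limits leave unreadable from compound 1 to compound 3.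

Compound 4 `CCOC(=O)c1c(-c2cccc(C)c2)[nH]c2cccc(OC)c2c1=O` differs from compound 3 by 3-methylphenyl in place of 2-methylphenyl on an aromatic carbon. No measured step bears directly on this change, and the one step shown gives no readable size. Since all three measured compounds sit at the limit of > 100000 nM in this assay, at which 3 of the 3 values shown sit, compound 4 is expected to reach the same limit, so the expected step is a step that the limit leaves unreadable from compound 3 to compound 4, nothing beyond the scatter. Compound 4 is estimated at 150000 nM in this assay, with a range from 60000 nM to 400000 nM.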

Compound 4, solubility: > 100000 nM
Compound 4 ended at the assay's limit (the forecaster's own chance of this, stated with the estimate: 85%); the middle value does not contradict the limit.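

No new step can be read between compound 4 and compound 3 or compound 1, because every value stands at one limit: the limit of > 100000 nM in this assay, at which 4 of the 4 values shown sit.

The compounds shown leave open whether any aryl group or methoxy position on the shared core changes the read-out in this assay.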